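The source may hold more compounds than are shown below. What is called first, only, known or untested is meant among the compounds shown, and "the series" means these compounds.

Measured compounds:
compound 1, `Oc1ccc(-c2cc(-c3ccsc3)cc(-c3cccc(O)c3)n2)cc1`: 17.1%
compound 2, `Oc1ccc(-c2cc(-c3ccoc3)cc(-c3ccccc3O)n2)cc1`: 30.1%

In an assay on isolated protein for inhibition of DNA topoisomerase 1 (Homo sapiens), with a stated time of 30 min, tested at 100 uM (a lower number here means a weaker effect, a higher number a stronger effect of the compound at the concentration tested), compound 1 gives 17.1%, and compound 2 gives 30.1%. Compound 2 therefore stands highest of the two numbers shown, with compound 1 as its only neighbour, lower by a margin that lies beyond the usual scatter of this kind of measurement.

Compound 3, `Oc1ccc(-c2cc(-c3ccoc3)cc(-c3cccc(O)c3)n2)cc1`, has not yet been measured. It keeps the core of compound 2 and differs from it in one place: 3-hydroxyphenyl in place of 2-hydroxyphenyl on an aromatic carbon. Among the compounds with values here, no pair of measured compounds that differ in exactly this way is available, so the size of the step from compound 2 to compound 3 in this assay cannot be read from the data; it can only be expected. A small downward step is expected, one that may well stay within the scatter, since compound 2 gives 30.1% and nothing shown argues for a large movement in either direction. The step from compound 2 to compound 3 is estimated as a number 7.1 percentage points lower from compound 2 to compound 3 (within the scatter). For compound 3 in this assay the estimated value is 23%, with a range from 8% to 40%.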

Compound 3, a percentage reported as inhibition, at one concentration (the size of the read-out at that concentration, not a potency): 37.4%
The estimate for compound 3 lay 14.4 percentage points below the measured number; measured number inside the range.
By their numbers in this assay, from the lowest: compound 1; then compounds 2 and 3 (each within the scatter of the next).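

In this assay, 3-hydroxyphenyl in place of 2-hydroxyphenyl on the aromatic carbon next to the ring nitrogen gives a number 7.3 percentage points higher from compound 2 to compound 3 (within the scatter) and so leaves the two hydroxyphenyl groups unresolved at this place, which means that this assay does not distinguish between them here. Within the data shown here, compound 3 also provides the first comparison in which only the five-membered ring group changes: with 3-hydroxyphenyl kept, furan-3-yl in place of thiophen-3-yl gives a number 20.3 percentage points higher from compound 1 to compound 3 (beyond the scatter) and thus, unlike the hydroxyl shift, produces a difference that stands clear of the scatter, though this rests on a single pair and a modest step. Nothing available explains the size of either step.

The compounds shown leave open whether the hydroxyl on this aryl group matters at all, since neither an unsubstituted phenyl, a methoxyphenyl nor an aminophenyl appears at this place, and the 4-hydroxyphenyl group stays the same throughout. Each number is also a read-out at a single concentration, so the potency of these compounds remains open.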